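Methoxy for Nitro: Expected Effect on Vero Cell Tolerance

The source may report more compounds than this note shows. Statements on the series, on what has been measured and on what is new or still open speak of the compounds shown alone.

Measured compounds:
compound 1 `O=[N+]([O-])c1cccc(/N=N/N2CCCCC2)c1` — 83000 nM
compound 2 `O=[N+]([O-])c1cccc(/N=N/Nc2cccc([N+](=O)[O-])c2)c1` — a limit of the assay, > 100000 nM
compound 3 `O=[N+]([O-])c1ccc(/N=N/N2CCCC2)cc1` — 90000 nM

All three were tested in an ADME assay on Vero cells (Chlorocebus sabaeus) for cytotoxicity, read by crystal violet staining; a higher number here means that more compound is tolerated, a lower number that less compound is tolerated. Compound 3 gives one of the two plain numbers in this assay; the other, from compound 1, lies within the usual scatter of it, so the two cannot be ranked against each other. Compound 2 returns only a limit, (the limit of > 100000 nM in this assay, at which 1 of the 3 values shown sits), and not a number.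

Compound 4 `COc1ccc(/N=N/N2CCCC2)cc1` has not yet been tested. It differs from compound 3 in a single place: methoxy in place of nitro on an aromatic carbon. Among the compounds with values here, no step between measured compounds covers this change, so there is no measured guide to its size or direction. Within the data shown here, the values known so far sit close together, and the change is expected to leave the number within the usual scatter of compound 3, with no shift in either direction beyond it. The step from compound 3 to compound 4 is therefore estimated as no change at the digits printed from compound 3 to compound 4 (within the scatter). Compound 4 is expected to give about 90000 nM, within a range from 40000 nM to 200000 nM, and there is a fair chance that this assay reports only a limit for it.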

Compound 4, half-maximal cytotoxic concentration: 90000 nM
Compound 4: the middle estimate sits on the measured number at the digits printed, within the range that was stated.
By their numbers in this assay, from the lowest: compounds 1, 3 and 4 (each within the scatter of the next). At a limit, above all of these: compound 2.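

In this assay, within the data shown here, putting methoxy in place of nitro on this aromatic carbon gives no change at the digits printed from compound 3 to compound 4 (within the scatter), the first step in this set between two compounds that differ in one place. Among these compounds, all the earlier compounds carry at least one nitro group, whereas compound 4 carries none and still gives 90000 nM, so at this place, para to a group of 7 heavy atoms, nitro is not required for a number of this size. Nothing in the data accounts for this lack of change, so the step records its size and gives no reason for it.

The compounds shown have only nitro and methoxy at this place, so a single step cannot say how another group there, such as an amine, a carboxylic acid or a longer chain, would read. Going by these compounds, whether the same exchange would also leave the number unchanged on a different core stays open too, as this one pair is no basis for a general rule.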